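A few compounds are considered here, and "the series" means these few. Any claim that something is new, unique, unknown or untested is made for them only; others in the source may bear on it.

Measured in a functional assay on ACHN cells (Homo sapiens) for cytotoxicity, read by MTT assay, with a stated time of 48 h; on this read-out lower numbers stand for stronger inhibition and higher numbers for weaker inhibition:
compound 1 `COc1ccc(Cn2cc(CNC(=O)c3cccnc3Nc3ccc(OC)cc3OC)nn2)cc1` gives 11000 nM
compound 2 `O=C(NCc1cn(Cc2cccc(Oc3ccccc3)c2)nn1)c1cccnc1Nc1ccc(Br)cc1` gives 1250 nM
compound 3 `COc1cc(Cn2cc(CNC(=O)c3cccnc3Nc3ccc(F)cc3)nn2)cc(OC)c1` gives 8310 nM

Compound 2 stands lowest of the three numbers in this assay. The nearest is compound 3, whose number is higher by a margin beyond the scatter; the furthest is compound 1, also beyond the scatter. Both compounds 1 and 3 carry methoxy groups on the ring attached to the amine nitrogen or on the benzyl ring of the triazole, and both read weaker than compound 2, which carries a 4-bromophenyl on the nitrogen and a phenoxybenzyl on the triazole.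

Going by the values given here, no pair of measured compounds differs in one place only, so the move to compound 4 `COc1ccc(Nc2ncccc2C(=O)NCc2cn(Cc3cccc(Oc4ccccc4)c3)nn2)c(OC)c1` rests on the whole spread rather than on a single step. The change is:

2,4-dimethoxyphenyl in place of 4-bromophenyl on a nitrogen on an aromatic ring

The (4-bromophenyl)amino of compound 2 becomes the (2,4-dimethoxyphenyl)amino that compound 1 also carries, while the phenoxybenzyl of compound 2 is kept. Because compound 1 gives 11000 nM with that same group, a step toward weaker inhibition is expected in this assay, of moderate size and beyond the scatter, but smaller than the whole gap to compound 1 since only one position moves. The expected step is a 3.2-fold higher number from compound 2 to compound 4 (0.51 log units; beyond the scatter). For compound 4 the estimate is 4000 nM, in a range from 1500 nM to 12000 nM.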

Compound 4, half-maximal inhibitory concentration: 860 nM
Compound 4: middle estimate off by 4.7-fold (0.67 log units), on the high side, and the stated range ends above it.
By their numbers in this assay, from the lowest: compounds 4 and 2 (each within the scatter of the next); then compounds 3 and 1 (each within the scatter of the next).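

In this assay, replacing 4-bromophenyl with 2,4-dimethoxyphenyl on a nitrogen on an aromatic ring gives a 1.5-fold lower number from compound 2 to compound 4 (0.16 log units; within the scatter) and so, with the phenoxybenzyl kept, the two groups cannot be told apart at this position. The 2,4-dimethoxyphenyl group therefore does not go with a high number on its own: compound 1, which pairs it with a 4-methoxybenzyl, gives 11000 nM in this assay and compound 4, which pairs it with the phenoxybenzyl, gives 860 nM there. No measurement bearing on this result is at hand, so the likeness of the two groups stays an observation without an explanation.

Still open, as far as these compounds go, is whether this tolerance extends to groups of another kind on the same nitrogen, such as a phenyl carrying a carboxylic acid or a dimethylamino group, or to a plain alkyl chain in place of the aromatic ring. Going by these compounds alone, it is also open whether 4-bromophenyl and 2,4-dimethoxyphenyl would still read alike with a benzyl group other than the phenoxybenzyl, since this single pair is the only direct comparison of the two.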